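The source may report more compounds than this note shows. Statements on the series, on what has been measured and on what is new or still open speak of the compounds shown alone.

Compound 1 `COc1cc(COc2ccc(C(=O)N/N=C/c3cc(C(C)(C)C)c(O)c(C(C)(C)C)c3)cc2)cc(OC)c1OC` and compound 2 `CCOc1cc(/C=N/NC(=O)c2ccc(OCc3cc(OC)c(OC)c(OC)c3)cc2)ccc1O` share a core and differ only in the phenol that hangs from the carbon double-bonded to nitrogen. In a physicochemical assay, with a stated time of 30 min (a lower number here means a stronger inhibitor, a higher number a weaker inhibitor), compound 1 gives 62 ug/mL. In this assay compound 2 gives 106 ug/mL, the highest of the two numbers, and the gap to compound 1 is within the scatter, so the two cannot be placed in order. Compound 3 `COc1cc(COc2ccc(C(=O)N/N=C/c3ccccc3O)cc2)cc(OC)c1OC` keeps the core of compound 2 and changes only that phenol: 2-hydroxyphenyl in place of 3-ethoxy-4-hydroxyphenyl on a carbon with a double bond to nitrogen. For the measured compounds named here, no measured pair shows this step, so its size can only be guessed from the two values in hand. Compound 2 and compound 1, with their more substituted phenols, sit close together, and the removal of the ethoxy group with the shift of the hydroxyl leaves nothing in the numbers to point the other way. It is expected that the step of a 1.9-fold higher number from compound 2 to compound 3 (0.28 log units; within the scatter) goes toward a higher number, somewhat beyond the scatter. The estimate for compound 3 in this assay is 200 ug/mL, with a range from 90 ug/mL to 500 ug/mL.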

Compound 3, half-maximal inhibitory concentration: > 100 ug/mL
Compound 3 was reported as a limit; the forecaster's own chance of this, stated with the estimate: 25%; the middle value lies beyond the limit too.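

In this assay, for the compounds shown here, compound 3 gives > 100 ug/mL, which is a limit and not a number, so no step from compound 2 to compound 3 can be read: the limit of > 100 ug/mL in this assay, at which 1 of the 3 values shown sits. The compounds shown leave open whether 2-hydroxyphenyl in place of 3-ethoxy-4-hydroxyphenyl changes the inhibition at all, and by how much.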